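This account rests on a few compounds, and the source may have more. Where it says the series, first, only, none or still open, it means among the compounds named here.

Working notes on the series. Compound 1 `O=[N+]([O-])c1ccccc1CNc1cc(C(F)(F)F)cc2[nH]ncc12`, compound 2 `O=C(O)CNc1cccc(CNc2cc(C(F)(F)F)cc3[nH]ncc23)c1` and compound 3 `O=[N+]([O-])c1cccc(CNc2cc(Br)cc3[nH]ncc23)c1` share one core and differ in the group on the outer ring and on the core. In an assay for inhibition of Indoleamine 2,3-dioxygenase 1 (Homo sapiens), with stated times of 10 min and 60 min (on this read-out higher numbers stand for weaker inhibition and lower numbers for stronger inhibition), compound 1 gives 14000 nM. In this assay compound 3 gives 7950 nM. Compound 2 returns no number in this assay, only the assay limit > 100000 nM. Compound 2 thus stands at the weak end of the values shown, at the limit of > 100000 nM in this assay, at which 1 of the 3 values shown sits.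

Compound 4 `FC(F)(F)c1cc(NCc2cccc(Br)c2)c2cn[nH]c2c1` has not been measured. It arises from compound 2 by the change (bromo in place of (carboxymethyl)amino on an aromatic carbon), on an aromatic carbon of a six-membered aromatic ring of carbon only, meta to a large group. Among the compounds with values here, no measured pair differs in one place, so the size of this step is not fixed by any measured step; the only numbers available are those of compound 1, 14000 nM, and compound 3, 7950 nM, and compound 4 is expected to land near them. The step of an at least 10-fold lower number from compound 2 to compound 4 (1.00 log units; beyond the scatter) is therefore expected to run toward stronger inhibition, beyond the scatter. Compound 4 is expected at 10000 nM, with a range from 3000 nM to 40000 nM.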

Compound 4, half-maximal inhibitory concentration: > 100000 nM
Compound 4 was reported as a limit; the forecaster's own chance of this, stated with the estimate: 15%; middle value at least 10-fold (1.00 log units) from the limit.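

In this assay, within the data shown here, compound 4 returns only a limit, > 100000 nM, and compound 2 likewise returns only a limit, so no step between these two compounds can be read; both sit at the weak end of the values shown: the limit of > 100000 nM in this assay, at which 2 of the 4 values shown sit.

Going by these compounds, whether bromo in place of (carboxymethyl)amino on an aromatic carbon changes inhibition at all remains open.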